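A carboxylic acid takes over from a fluorinated ring

The source may report more compounds than this note shows. Statements on the series, on what has been measured and on what is new or still open speak of the compounds shown alone.

Measured so far in an ADME assay on a cell-free system (plasma, Rattus norvegicus) for metabolic stability, read by LC-MS, with a stated time of 1 h, at 37 degrees C, tested at 100 uM; a lower number here means that less of the compound is left, a higher number that more of the compound is left:
Compound 1 `O=C(O)c1cc(-c2cccc(COc3ccc4c(c3)CN(C3CCCC3)C4=O)c2)ccc1O`: 98%
Compound 2 `O=C1c2ccc(OCc3cccc(-c4ccc(C(F)(F)F)cc4F)c3)cc2CN1C1CCCC1`: "not determined" (no result reported)

Compound 2 has no single number in this assay, so it cannot be placed on the scale and gives no baseline for what follows. The next compound is compound 3 `Cc1ccc(C(=O)O)cc1-c1cccc(COc2ccc3c(c2)CN(C2CCCC2)C3=O)c1`, which has not yet been measured. The change is 5-carboxy-2-methylphenyl in place of 2-fluoro-4-(trifluoromethyl)phenyl on an aromatic carbon, meta to a large group. For the measured compounds named here, no measured step shows what such a change does, and the size of a step from a missing value cannot be stated. The nearest guide is compound 1, which shares the core, also carries a carboxy group and gives 98%. No difference from compound 1 beyond the usual scatter is expected, in either direction. Compound 3 is expected at 95%, with an estimated range of 82% to 105%.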

Compound 3, percent of the compound remaining: 100%
Compound 3: middle estimate off by 5 percentage points, on the low side; measured number inside the range.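

In this assay the step on this aromatic carbon is a number 2 percentage points higher from compound 1 to compound 3 (within the scatter), so 5-carboxy-2-methylphenyl and 3-carboxy-4-hydroxyphenyl cannot be told apart here. Compound 1 alone offered a single ring bearing a carboxy group at this place, whereas compound 3 adds a second such ring, one that carries a methyl group rather than a hydroxy group. Nothing measured on these compounds offers an explanation for this reading.

Compound 2 has no number, so the steps to it cannot be read, and both compounds with a value carry a carboxylic acid, which leaves the effect of that group itself unsettled. Also open, from the compounds shown here alone, is how the compounds would fare in this assay with an amine or a nitrile on this ring.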